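Bromo in place of hydrogen on compound 2

This account rests on a few compounds, and the source may have more. Where it says the series, first, only, none or still open, it means among the compounds named here.

Values measured so far in a functional assay on HepG2 cells (Homo sapiens) for antiproliferative activity, read by sulforhodamine B assay, with a stated time of 48 h (on this read-out lower numbers stand for stronger inhibition and higher numbers for weaker inhibition), for two compounds
Compound 1 `COc1cccc(/C=C/C(=O)C(=Cc2ccc(O)c(F)c2)C(=O)/C=C/c2cccc(OC)c2OC)c1OC` gives 220 nM
Compound 2 `COc1ccc(/C=C/C(=O)C(=Cc2ccc(O)c(OC)c2)C(=O)/C=C/c2ccc(OC)cc2OC)c(OC)c1` gives 510 nM

Compound 2 at 510 nM holds the higher of the two numbers, and compound 1 at 220 nM lies lower by more than the scatter. Compound 3 `COc1ccc(/C=C/C(=O)C(=Cc2cc(Br)c(O)c(OC)c2)C(=O)/C=C/c2ccc(OC)cc2OC)c(OC)c1` still awaits measurement. It differs from compound 2 by bromo in place of hydrogen on an aromatic carbon, ortho to a hydroxy group and meta to a methoxy group, which turns 4-hydroxy-3-methoxyphenyl into 3-bromo-4-hydroxy-5-methoxyphenyl bromo in place of hydrogen on an aromatic carbon at that one place. Among the measured compounds shown here, the two measured compounds differ in more than one place, so no measured step speaks to this change. A modest step toward a lower number in this assay is expected, possibly no larger than the scatter. The expected move is a 1.5-fold lower number from compound 2 to compound 3 (0.16 log units; within the scatter) in this estimate. Compound 3 is estimated at 350 nM with an expected range of 120 nM to 1000 nM for repeated measurements.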

Compound 3, half-maximal inhibitory concentration: 1190 nM
Compound 3: middle estimate off by 3.4-fold (0.53 log units), on the low side; the whole stated range lies below it.
By their numbers in this assay, from the lowest: compound 1; then compound 2; then compound 3.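

In this assay, among the compounds shown here, this is the first step that isolates a single place, and it goes toward weaker inhibition: bromo in place of hydrogen on the aromatic carbon ortho to the hydroxy group and meta to the methoxy group gives a 2.3-fold higher number from compound 2 to compound 3 (0.37 log units; beyond the scatter), a modest change but beyond the scatter. On this compound pair, then, hydrogen at this position is better for the read-out than bromo, and turning 4-hydroxy-3-methoxyphenyl into 3-bromo-4-hydroxy-5-methoxyphenyl does not strengthen inhibition. Nothing measured here accounts for the loss. Going by these compounds, whether chloro, an amine or a carboxylic acid on that same carbon would also raise the number remains open. So does whether bromo would produce a step of similar size and direction on the other compounds of the series.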